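This account rests on a few compounds, and the source may have more. Where it says the series, first, only, none or still open, it means among the compounds named here.

Working notes on the benzofuran-carboxamide series. Compound 1 `COC(=O)C(C)(C)NC(=O)c1cc(F)cc2cc(-c3ccc(Cl)cc3)oc12` carries the methyl ester; in an assay on isolated protein for inhibition of endoplasmic reticulum aminopeptidase 2 (Homo sapiens) (on this read-out higher numbers stand for weaker inhibition and lower numbers for stronger inhibition), compound 1 gives "not determined" (no result reported), so no number anchors it. Compound 2 `O=C(NC1(C(=O)O)Cc2ccccc2C1)c1cc(F)cc2cc(-c3ccc(Cl)cc3)oc12` is recorded only as a limit of this assay, > 30000 nM. Compound 3 `CC(C)(NC(=O)c1cccc2cc(-c3ccc(Cl)cc3)oc12)C(=O)O` likewise sits at a limit, > 30000 nM. Both carboxylic acids thus reach the limit of > 30000 nM in this assay, at which 2 of the 3 values shown sit, and give no measurable inhibition. Compound 4 `O=C(NC1(C(=O)O)CCCC1)c1cc(F)cc2cc(-c3ccc(Cl)cc3)oc12` is the next member to be measured. It differs from compound 1 by 1-carboxycyclopentyl in place of 1-(methoxycarbonyl)-1-methylethyl on an amide-type nitrogen. Within the data shown here, no step between measured compounds is available, so the size and direction of this change in this assay cannot be read from the data; the two acids suggest another limit. Compound 4 is therefore expected to read 60000 nM, within 10000 nM to 300000 nM.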

Compound 4, half-maximal inhibitory concentration: > 30000 nM
Compound 4 gave a limit, no number (the forecaster's own chance of this, stated with the estimate: 75%); the middle value is on the limit's open side.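

No step can be read between compound 1 and compound 4; compound 4 is recorded only as a limit, not a number: the limit of > 30000 nM in this assay, at which 3 of the 4 values shown sit. The compounds shown leave open what value any member of this series would give in this assay.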